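Replacing an Anilide by a Pyrrolidine Amide

A few compounds are considered here, and "the series" means these few. Any claim that something is new, unique, unknown or untested is made for them only; others in the source may bear on it.

Measured so far:
Compound 1, `CCOc1ccc(NC(=O)c2cccc(/C=C3\CC(=O)N(c4ccccc4)C3=O)c2)cc1`: in an ADME assay on SW480 cells (Homo sapiens) for cytotoxicity, read by MTT assay, with a stated time of 72 h (on this read-out lower numbers stand for stronger inhibition and higher numbers for weaker inhibition), compound 1 gives 91500 nM.
Compound 2, `Cc1ccc(NC(=O)c2cccc(/C=C3\CC(=O)N(c4ccccc4)C3=O)c2)cc1C`: in this assay compound 2 gives > 100000 nM, which is a limit of the assay.
Compound 3, `O=C(Nc1cccc(F)c1)c1cccc(/C=C2\CC(=O)N(c3ccccc3)C2=O)c1`: in this assay compound 3 gives > 100000 nM, which is a limit of the assay.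

For the measured compounds named here, compound 3 thus stands at the limit, and the only true number among the three belongs to compound 1. The steps of an at least 1.0-fold higher number from compound 1 to compound 2 (0.03 log units; that floor lies within the scatter) and an at least 1.0-fold higher number from compound 1 to compound 3 (0.03 log units; that floor lies within the scatter) are floors that lie within the scatter, and the step that the two limits leave unreadable from compound 2 to compound 3 cannot be read. Two of the three values sit at the limit of > 100000 nM in this assay, at which 2 of the 3 values shown sit.

Compound 4, `O=C(c1cccc(/C=C2\CC(=O)N(c3ccccc3)C2=O)c1)N1CCCC1`, differs from compound 3 by pyrrolidin-1-yl in place of (3-fluorophenyl)amino on a carbonyl carbon. Going by the values given here, none of the measured steps changes the amide in this way; they vary only the aryl group on its nitrogen, and none of them moved the read-out in this assay beyond the scatter. Compound 4 is therefore expected to remain in the same weak region, the expected step being a number no higher from compound 3 to compound 4 (the limit leaves the size open). The estimate for compound 4 in this assay is 100000 nM, expected to range from 40000 nM to 250000 nM.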

Compound 4, half-maximal inhibitory concentration: > 100000 nM
Compound 4 ended at the assay's limit (the forecaster's own chance of this, stated with the estimate: 60%); the middle value sits exactly at the limit.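

Unlike the earlier steps, which varied only the aryl group on the amide nitrogen, this change replaces the whole (3-fluorophenyl)amino group, with its hydrogen-bond donor and aromatic ring, by pyrrolidin-1-yl, and in this assay the read-out still shows no measurable gain in cytotoxicity. For the compounds shown here, the one readable step is an at least 1.0-fold higher number from compound 1 to compound 4 (0.03 log units; that floor lies within the scatter). The steps to compound 4 from compound 2 and compound 3 cannot be read, because both ends of each are limits of the assay: the limit of > 100000 nM in this assay, at which 3 of the 4 values shown sit.

With so many values at the limit, any differences among these compounds stay hidden, and the comparison rests on compound 1 alone. Going by these compounds, it remains open whether a piperazine, a morpholine or an aminoalkyl chain on this carbonyl carbon would bring a value below the limit.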